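Fluoro for hydrogen on a compound at the assay limit

The source may hold more compounds than are shown below. What is called first, only, known or untested is meant among the compounds shown, and "the series" means these compounds.

In a functional assay on Vero cells (Chlorocebus sabaeus) for inhibition (on this read-out higher numbers stand for weaker inhibition and lower numbers for stronger inhibition), compound 1 (`Nc1nc(F)nc2c1ncn2[C@H]1CS[C@@H](CO)O1`) gives 5600 nM as a measured number. Compound 2 (`O=C1NC(O)C=CN1[C@@H]1CS[C@@H](CO)O1`) gives > 100000 nM and this is a limit of the assay, not a number. Compound 3 (`O=C1NC(O)C(F)=CN1[C@@H]1CS[C@@H](CO)O1`) is not yet measured and differs from compound 2 in one place (fluoro in place of hydrogen on a double-bonded ring carbon) with fluoro in place of hydrogen on a double-bonded ring carbon. For the measured compounds named here, no measured pair shows such a change in this assay so the expectation rests on the starting point alone. A small shift toward stronger inhibition is expected, and the reading may well stay at the limit. The change expected is an at least 1.6-fold lower number from compound 2 to compound 3 (0.22 log units; that floor lies within the scatter) in size, toward stronger inhibition. For compound 3 the estimate is 60000 nM with an expected range from 12000 nM to 150000 nM in this read-out.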

Compound 3, half-maximal inhibitory concentration: > 100000 nM
Compound 3 was reported as a limit (the forecaster's own chance of this, stated with the estimate: 60%); middle value at least 1.6-fold (0.22 log units) from the limit.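

No step can be read from compound 2 to compound 3 in this assay, because both values are limits and not numbers: the limit of > 100000 nM in this assay, at which 2 of the 3 values shown sit.

On these data alone, whether fluoro in place of hydrogen on a double-bonded ring carbon changes inhibition at all remains open for these two compounds.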